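The compounds below may be only part of what the source reports. "The series", "measured", "known", "first", "only" and "open" are said of these compounds alone.

Measured in a functional assay on K562 cells (Homo sapiens) for antiproliferative activity, with a stated time of 72 h; on this read-out higher numbers stand for weaker inhibition and lower numbers for stronger inhibition:
- compound 1 `OC[C@H]1O[C@@H](n2cnc3c(NCc4ccc(F)cc4)ncnc32)[C@H](O)[C@@H]1O`: 2700 nM
- compound 2 `Cc1ccc(CNc2ncnc3c2ncn3[C@@H]2O[C@H](CO)[C@@H](O)[C@H]2O)cc1`: > 166000 nM, a limit

The value of compound 2, > 166000 nM, is a limit and not a number. Compound 3 `OC[C@H]1O[C@@H](n2cnc3c(NCc4ccc(OC(F)(F)F)cc4)ncnc32)[C@H](O)[C@@H]1O` carries trifluoromethoxy in place of methyl on an aromatic carbon, para to a large group: trifluoromethoxy in place of methyl on an aromatic carbon. Given an at least 61-fold higher number from compound 1 to compound 2 (1.78 log units; beyond the scatter), a large step with methyl in place of fluoro on an aromatic carbon, a sizeable move to a lower number is expected in this assay once methyl leaves, though perhaps a smaller one. The expected change is an at least 6.6-fold lower number from compound 2 to compound 3 (0.82 log units; beyond the scatter). For compound 3 the estimate is 25000 nM, with an expected range of 2500 nM to 166000 nM.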

Compound 3, half-maximal inhibitory concentration: > 166000 nM
Compound 3 ended at the assay's limit (the forecaster's own chance of this, stated with the estimate: 40%); at least 6.6-fold (0.82 log units) between middle value and limit.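

In this assay compound 3 gives > 166000 nM, which is a limit and not a number. Trifluoromethoxy in place of fluoro on this aromatic carbon, para to a large group, gives an at least 61-fold higher number from compound 1 to compound 3 (1.78 log units; beyond the scatter), so methyl is no longer the only replacement of fluoro here with this outcome. The step between the two compounds that carry methyl and trifluoromethoxy cannot be read: the limit of > 166000 nM in this assay, at which 2 of the 3 values shown sit.

The compounds shown leave open whether chloro, hydroxyl or an amine at this position would give a measurable value. They also leave open how compound 2 and compound 3 rank against each other.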